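The compounds below may be only part of what the source reports. "The series", "measured", "known", "first", "only" and "open" are said of these compounds alone.

Two compounds have a number in an assay on HEK293 cells for inhibition of Voltage-dependent T-type calcium channel subunit alpha-1G (Homo sapiens), read by patch clamp; a lower number here means a stronger inhibitor, a higher number a weaker inhibitor. Compound 1, `O=C(CCCCN1CCN(c2cccc(Cl)c2)CC1)Nc1ccccc1Cl`, gives 1910 nM in this assay. Compound 2, `O=C(CCCN1CCN(c2ccc(F)cc2)CC1)Nc1ccc(Cl)cc1`, gives 3490 nM in this assay, the higher of the two numbers; the nearest number is that of compound 1, and the gap between compound 2 and compound 1 lies within the scatter of repeated measurements, so the two cannot be set in order. Among the compounds with values here, the two compounds differ in more than one place, and no single step between them is recorded.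

Compound 3, `COc1ccccc1N1CCN(CCCC(=O)Nc2ccc(Cl)cc2)CC1`, has not yet been measured. It differs from compound 2 in one place: 2-methoxyphenyl in place of 4-fluorophenyl on an amine nitrogen in a ring. Within the data shown here, no measured pair shows this change on its own, so the direction of the step is open. The account expects a small step toward a lower number, one that would not clearly leave the scatter, with the step from a 1.6-fold lower number from compound 2 to compound 3 (0.20 log units; within the scatter) as the working guess. Compound 3 is expected to give about 2200 nM in this assay, with a plausible range from 600 nM to 8000 nM; the measurement will decide.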

Compound 3, half-maximal inhibitory concentration: 2610 nM
Compound 3: middle estimate off by 1.2-fold (0.07 log units), on the low side; low and high end bracket the measured number.
By their numbers in this assay, from the lowest: compounds 1, 3 and 2 (each within the scatter of the next).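

In this assay, putting 2-methoxyphenyl in place of 4-fluorophenyl on an amine nitrogen in a ring gives a 1.3-fold lower number from compound 2 to compound 3 (0.13 log units; within the scatter). Within the data shown here, this is the first single change at this position, and it shows that the assay does not separate these two groups here, even though the entering group has 8 heavy atoms against 7 and 1 hydrogen-bond acceptor against 0. With only this pair, the result describes this one exchange on this one background, and nothing shown bears on why the two groups read alike.

Going by these compounds, it remains open whether a group of a different kind on this nitrogen, such as benzyl or acetyl, would give a step that clearly leaves the scatter, or whether 2-methoxyphenyl and 4-fluorophenyl would still read alike with a longer chain in the molecule. Compound 1 differs from compound 3 in more than one place, so it cannot settle either question.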